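Notes on compound 4 against its measured neighbours

The source may report more compounds than this note shows. Statements on the series, on what has been measured and on what is new or still open speak of the compounds shown alone.

Three compounds on the shared core have numbers in an assay on HeLa cells for inhibition of sphingosine-1-phosphate transporter SPNS2 (Mus musculus), read by LC-MS, tested at 2 uM; a higher number here means more inhibition at the concentration tested (going by the name of the read-out), a lower number less inhibition. Compound 1 `CCCCCCCCCCc1ccc(-c2noc([C@H]3CCCN3)n2)cc1` gives 12%; compound 2 `CCCCCCCCCCc1ccc(-c2noc(C3CCNCC3)n2)cc1` gives 66%; compound 3 `CCCCCCCCCCc1ccc(-c2noc(CC[C@@H](N)C(=O)O)n2)cc1` gives 5%. Compound 3 has the lowest of the three numbers, but one of its gaps is within the scatter (a number 7 percentage points lower from compound 1 to compound 3 (within the scatter)), while the other is large (a number 61 percentage points lower from compound 2 to compound 3 (beyond the scatter)); the step of a number 54 percentage points higher from compound 1 to compound 2 (beyond the scatter) is likewise large.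

Compound 4 `CCCCCCCCCCc1ccc(-c2noc(CC(O)CN3CCCCC3)n2)cc1` is reached from compound 3 by 1-hydroxy-2-(piperidin-1-yl)ethyl in place of 2-amino-2-carboxyethyl on a saturated chain carbon bound to an aromatic carbon. The step that bears on it is a number 61 percentage points lower from compound 2 to compound 3 (beyond the scatter), in which the piperidin-4-yl of compound 2 was lost and the amino acid chain arrived; compound 4 removes that chain again and brings in a piperidin-1-yl, though on a hydroxy-bearing chain rather than on the aromatic carbon. For the measured compounds named here, a rise in this assay is therefore expected, of a size approaching the reverse of that step but with wide uncertainty, since no measured compound carries a saturated amine on such a chain. The step of a number 45 percentage points higher from compound 3 to compound 4 (beyond the scatter) is the expected result, giving compound 4 an estimated 50% with a range from 20% to 80%.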

Compound 4, a percentage reported as inhibition, at one concentration (the size of the read-out at that concentration, not a potency): 2%
Estimate against measurement, compound 4: 48 percentage points above, and the stated range ends above it.
By their numbers in this assay, from the lowest: compounds 4, 3 and 1 (each within the scatter of the next); then compound 2.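

In this assay, a piperidine ring carried on a hydroxy-bearing chain at this place does not match the piperidin-4-yl of compound 2: the change to 2-hydroxy-3-(piperidin-1-yl)propyl reads a number 64 percentage points lower from compound 2 to compound 4 (beyond the scatter). Against the amino acid chain it reads a number 3 percentage points lower from compound 3 to compound 4 (within the scatter), and against the pyrrolidin-2-yl a number 10 percentage points lower from compound 1 to compound 4 (within the scatter), so among these four groups only the piperidin-4-yl stands apart. Nothing measured alongside these numbers accounts for this.

On these data alone, it remains open whether the number for compound 2 depends on the ring being joined directly through a ring carbon, or whether the hydroxy-bearing chain itself matters. A piperidin-3-yl, a piperidin-4-ylmethyl and a plain 3-(piperidin-1-yl)propyl without the hydroxyl would separate these possibilities.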